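The compounds below may be only part of what the source reports. "The series", "measured", "known", "first", "only" and "open" are said of these compounds alone.

Compound 1 `C=C(Br)C(=O)Nc1cccc(-c2cn3nc(Cc4ccccc4)sc3n2)c1`: 3000 nM
Compound 2 `C=C(Br)C(=O)Nc1cccc(-c2cn3nc(-c4ccc(OCC)cc4)sc3n2)c1`: 790 nM
Compound 3 `C=C(Br)C(=O)Nc1cccc(-c2cn3nc(-c4ccc(C)cc4)sc3n2)c1`: 920 nM

In a functional assay on L1210 cells (Mus musculus) for inhibition, read by cell counting, with a stated time of 2 days (a lower number here means a stronger inhibitor, a higher number a weaker inhibitor), compound 3 stands second highest of the three numbers: compound 2 lies within the scatter of it, a 1.2-fold higher number from compound 2 to compound 3 (0.07 log units; within the scatter), while compound 1 is further off, a 3.3-fold lower number from compound 1 to compound 3 (0.51 log units; beyond the scatter). Compound 4 `C=C(Br)C(=O)Nc1cccc(-c2cn3nc(-c4ccc(Cl)cc4)sc3n2)c1` differs from compound 3 by chloro in place of methyl on an aromatic carbon. Among the compounds with values here, no measured step introduces chloro. Within the data shown here, the only step at the same position, a 1.2-fold higher number from compound 2 to compound 3 (0.07 log units; within the scatter), stayed within the scatter; the two steps that went beyond it, a 3.8-fold lower number from compound 1 to compound 2 (0.58 log units; beyond the scatter) and a 3.3-fold lower number from compound 1 to compound 3 (0.51 log units; beyond the scatter), concern the exchange of benzyl for an aryl group and do not bear on this change. For compound 4 in this assay a number near that of compound 3 is therefore expected; the expected step is a 1.0-fold lower number from compound 3 to compound 4 (0.01 log units; within the scatter), none beyond the scatter. Compound 4 is estimated at 900 nM, range 400 nM to 2000 nM.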

Compound 4, half-maximal inhibitory concentration: 1400 nM
The estimate for compound 4 lay 1.6-fold (0.19 log units) below the measured number; low and high end bracket the measured number.
By their numbers in this assay, from the lowest: compounds 2, 3 and 4 (each within the scatter of the next); then compound 1.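

In this assay, chloro at this place, para to a large group, gives a number within the scatter of both methyl (a 1.5-fold higher number from compound 3 to compound 4 (0.18 log units; within the scatter)) and ethoxy (a 1.8-fold higher number from compound 2 to compound 4 (0.25 log units; within the scatter)). The advantage of a directly attached aryl group over benzyl also extends to 4-chlorophenyl (a 2.1-fold lower number from compound 1 to compound 4 (0.33 log units; beyond the scatter)), though this is based on compound 1 alone. No evidence on the cause of these numbers is at hand.

On these data alone, whether an amine, a carboxylic acid or a longer alkoxy chain at this place would also stay within the scatter remains open. So does the effect of moving chloro elsewhere on the ring.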